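Replacing the amino group with furan-2-yl on the shared core

The source may report more compounds than this note shows. Statements on the series, on what has been measured and on what is new or still open speak of the compounds shown alone.

The three measured compounds share one core and differ only at a single aromatic carbon. Compound 1 `CN(C)c1ncnc2[nH]cc(Sc3cccs3)c12` carries a dimethylamino group there; in an ADME assay on MRC5 cells (Homo sapiens), read by MTT assay, with a stated time of 3 days (a lower number here means a stronger inhibitor, a higher number a weaker inhibitor), compound 1 gives only a limit of the assay, > 150000 nM (the limit of > 150000 nM in this assay, at which 1 of the 3 values shown sits). Compound 2 `CNc1ncnc2[nH]cc(Sc3cccs3)c12` carries a methylamino group and gives 148000 nM in this assay. Compound 3 `Nc1ncnc2[nH]cc(Sc3cccs3)c12` carries the amino group and gives 136000 nM in this assay. Among the two real numbers, compound 3 stands lowest, with compound 2 as its nearest neighbour; the step of a 1.1-fold lower number from compound 2 to compound 3 (0.04 log units; within the scatter) lies within the scatter, as do an at least 1.0-fold lower number from compound 1 to compound 2 (0.00 log units; that floor lies within the scatter) and an at least 1.1-fold lower number from compound 1 to compound 3 (0.04 log units; that floor lies within the scatter).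

Compound 4 `c1coc(-c2ncnc3[nH]cc(Sc4cccs4)c23)c1` is not yet measured. It differs from compound 3 in one place: furan-2-yl in place of amino on an aromatic carbon. Among the compounds with values here, none of the measured steps removes the amino group or introduces an aromatic ring; they only add or take away methyl groups on the nitrogen, and every one of them stayed within the scatter. They therefore give little guidance on this larger change, and the account can only expect a number not far from compound 3, with a modest lowering as the more likely direction.

The estimated step of a 1.5-fold lower number from compound 3 to compound 4 (0.18 log units; within the scatter) expresses this expectation. Compound 4 is expected to give about 90000 nM in this assay, within a range of 25000 nM to 150000 nM.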

Compound 4, half-maximal inhibitory concentration: 32900 nM
Beside the measured number, compound 4's estimate is 2.7-fold (0.44 log units) above it, within the range that was stated.
By their numbers in this assay, from the lowest: compound 4; then compounds 3 and 2 (each within the scatter of the next). At a limit, above all of these: compound 1.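

Among the amino, methylamino and dimethylamino groups at this aromatic carbon, no step moved beyond the scatter, but furan-2-yl in place of amino gives in this assay a 4.1-fold lower number from compound 3 to compound 4 (0.62 log units; beyond the scatter), the first change at this position that registers. Measured against the methylamino group the change is of similar size, with a 4.5-fold lower number from compound 2 to compound 4 (0.65 log units; beyond the scatter), and against the dimethylamino group only a floor can be read, an at least 4.5-fold lower number from compound 1 to compound 4 (0.65 log units; beyond the scatter). So replacing the nitrogen-linked group with a five-membered aromatic ring does what trimming methyl groups from the nitrogen did not, and compound 4 is the only one of the four set clearly apart from the others, while compound 1 remains at a limit of the assay and not a number: the limit of > 150000 nM in this assay, at which 1 of the 4 values shown sits.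

The compounds shown do not separate the loss of the amino group from the arrival of the furan-2-yl ring, and a phenyl ring, a thiophene ring or a plain methyl group at this carbon could tell the two apart. From the compounds shown here alone, whether a saturated amine such as morpholine would behave like the amino groups or like furan-2-yl also stays open.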